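The source may hold more compounds than are shown below. What is called first, only, known or untested is meant among the compounds shown, and "the series" means these compounds.

Of the compounds shown here, three built on one shared core have been measured in a functional assay on MCF7 cells (Homo sapiens) for antiproliferative activity, read by MTT assay, with a stated time of 24 h; a higher number here means a weaker inhibitor, a lower number a stronger inhibitor. Compound 1 `Cc1ccc(-c2nn(-c3ccccc3)cc2-c2nc3ccccc3n2S(=O)(=O)c2ccc(Cl)cc2)cc1` gives 5930 nM. Compound 2 `Cc1ccc(-c2nn(-c3ccccc3)cc2-c2nc3ccccc3n2S(=O)(=O)c2ccc(Br)cc2)cc1` gives 3160 nM. Compound 3 `Cc1ccc(-c2nn(-c3ccccc3)cc2-c2nc3ccccc3n2S(=O)(=O)c2ccc(C(F)(F)F)cc2)cc1` gives 2340 nM, which stands at the low end of the three numbers, though its gap to compound 2 lies within the scatter, and only its step from compound 1 counts as a real difference, a 2.5-fold lower number from compound 1 to compound 3 (0.40 log units; beyond the scatter). The remaining steps, a 1.9-fold lower number from compound 1 to compound 2 (0.27 log units; within the scatter) and a 1.4-fold lower number from compound 2 to compound 3 (0.13 log units; within the scatter), are both small. All three measured steps exchange one substituent for another on a ring other than the one changed here.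

Compound 4 `O=S(=O)(c1ccc(C(F)(F)F)cc1)n1c(-c2cn(-c3ccccc3)nc2-c2ccc(F)cc2)nc2ccccc21` differs from compound 3 in a different place: fluoro in place of methyl on an aromatic carbon. Among the measured compounds shown here, none of the measured steps touches this ring, so the data give no direct reading of how the assay responds to such a swap. What the measured steps do show is that single-group exchanges on an aromatic ring in this series have moved the number only modestly at most. Compound 4 is therefore expected to land close to compound 3, with a 1.1-fold higher number from compound 3 to compound 4 (0.05 log units; within the scatter) expected to stay within the scatter. The estimate for compound 4 is 2600 nM, with a range from 1100 nM to 6200 nM.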

Compound 4, half-maximal inhibitory concentration: 1580 nM
Beside the measured number, compound 4's estimate is 1.6-fold (0.22 log units) above it; measured number inside the range.
By their numbers in this assay, from the lowest: compounds 4, 3, 2 and 1 (each within the scatter of the next, the first and the last beyond it).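

Among the compounds shown here, compound 4 gives the first reading at this position, the carbon para to a large group on the ring that carries the methyl in compounds 1 to 3. All earlier steps changed a substituent on a different ring. Exchanging 4-methylphenyl for 4-fluorophenyl gives a 1.5-fold lower number from compound 3 to compound 4 (0.17 log units; within the scatter), so in this assay compound 3 and compound 4 cannot be told apart, and this position accepts fluoro in place of methyl with no change that stands clear of the usual variation between repeats. Nothing available here explains this result, and a single pair with trifluoromethyl on the other ring says nothing about how the assay would respond to a larger change at this carbon.

It remains open whether the same exchange would read the same way with chloro or bromo on the other ring, since the fluoro group is shown only alongside trifluoromethyl. Also open, as far as these compounds go, is whether this position stays as forgiving with an unsubstituted phenyl ring or with a different group on it, such as a methoxy group, an amine or a carboxylic acid.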